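Configuration at the ring carbon: working notes

This account rests on a few compounds, and the source may have more. Where it says the series, first, only, none or still open, it means among the compounds named here.

compound 1 `Nc1ncnc2c1ncn2/C=C1/C[C@@H]1[C@H](O)CO` gives 50500 nM
compound 2 `Nc1ncnc2c1ncn2/C=C1\C[C@@H]1[C@@H](O)CO` gives 50600 nM

Among the compounds with values here, in an ADME assay on Akata cells (Homo sapiens) for cytotoxicity (a higher number here means that more compound is tolerated, a lower number that less compound is tolerated), compound 2 (50600 nM) sits level with compound 1, the only other number so far, and the gap lies within the scatter. Compound 3 `Nc1ncnc2c1ncn2/C=C1\C[C@H]1[C@@H](O)CO` departs from compound 2 by one change (the two compounds have the same atoms and bonds and differ only in configuration as drawn: 1 of 3 stereo elements differ; a stereocentre at a saturated ring carbon is drawn S in compound 2 and R in compound 3), in which a stereocentre at a saturated ring carbon is drawn S in compound 2 and R in compound 3. Within the data shown here, the one measured step that bears on this is a 1.0-fold higher number from compound 1 to compound 2 (0.00 log units; within the scatter) and it too alters configuration only (the fact that compounds 1 and 2 differ only in the configuration as drawn), at a saturated chain carbon and the double bond, not at the ring carbon. Among the measured compounds shown here, the ring stereocentre has no measured step of its own. No shift beyond the scatter is therefore expected in this assay for compound 3. The estimated step is a 1.0-fold lower number from compound 2 to compound 3 (0.01 log units; within the scatter) and so stays within the scatter. Compound 3 is estimated at 50000 nM with 25000 nM to 100000 nM as its expected range.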

Compound 3, half-maximal cytotoxic concentration: 73000 nM
Compound 3: middle estimate off by 1.5-fold (0.16 log units), on the low side; measured number inside the range.
By their numbers in this assay, from the lowest: compounds 1, 2 and 3 (each within the scatter of the next).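

In this assay the stereocentre at the saturated ring carbon now has a measured step of its own (a 1.4-fold higher number from compound 2 to compound 3 (0.16 log units; within the scatter)), and drawing it R rather than S leaves compounds 2 and 3 level. With all three stereo elements differing at once, the result is the same (a 1.4-fold higher number from compound 1 to compound 3 (0.16 log units; within the scatter)), so no configuration shown at the ring carbon, the chain carbon or the double bond separates these compounds beyond the scatter. Only configuration separates compounds 2 and 3: the fact that compounds 2 and 3 differ only in the configuration as drawn.

From the compounds shown here alone, all three compounds share the same atoms and bonds, so the effect of any change of group on tolerance in these cells remains open. Also open, going by these compounds, is whether an amine or a carboxylic acid in place of a hydroxyl group on the chain would stay level with these compounds.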